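The compounds below may be only part of what the source reports. "The series", "measured", "known", "first", "only" and "open" are said of these compounds alone.

In a functional assay on MDA-MB-231 cells (Homo sapiens) for antiproliferative activity, read by MTT assay, with a stated time of 24 h (on this read-out higher numbers stand for weaker inhibition and lower numbers for stronger inhibition), compound 1 `Cc1cccc(NNC(=O)c2cccc(NS(=O)(=O)c3cnc(O)nc3O)c2)c1` gives > 20000 nM, which is a limit and not a number. Among the compounds with values here, compound 2 `O=C(NNC(=O)c1ccccc1Cl)c1cccc(NS(=O)(=O)c2cnc(O)nc2O)c1` gives 2360 nM, the only true number so far. Within the data shown here, the one measured step is an at least 8.4-fold lower number from compound 1 to compound 2 (0.92 log units; beyond the scatter), and it rests on (the limit of > 20000 nM in this assay, at which 1 of the 2 values shown sits), so its full size stays open. Compound 3 `O=C(NNC(=O)c1cccc(NS(=O)(=O)c2cnc(O)nc2O)c1)c1ccc(F)cc1` keeps the shared core and differs from compound 2 as follows: 4-fluorophenyl in place of 2-chlorophenyl on a carbonyl carbon. That is 4-fluorophenyl in place of 2-chlorophenyl on a carbonyl carbon. Among the measured compounds shown here, the measured step exchanged a different pair of groups, and no measured step covers this swap, so it sets no size here. Both compounds carry a substituted phenyl on that carbonyl, so the expectation stays close to compound 2 at 2360 nM. The expected change is a 1.5-fold higher number from compound 2 to compound 3 (0.17 log units; within the scatter), leaning slightly towards weaker inhibition but not beyond the scatter. For compound 3 the estimated value is 3500 nM, with an expected range from 1200 nM to 12000 nM.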

Compound 3, half-maximal inhibitory concentration: > 20000 nM
Compound 3 was reported as a limit (the forecaster's own chance of this, stated with the estimate: 15%); at least 5.7-fold (0.75 log units) between middle value and limit.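

Having a substituted phenyl on this carbonyl carbon does not by itself keep the activity: in this assay, 4-fluorophenyl in place of 2-chlorophenyl gives an at least 8.4-fold higher number from compound 2 to compound 3 (0.92 log units; beyond the scatter). From the compounds shown here alone, compound 3 gives > 20000 nM, which is a limit and not a number, so the full size of this step stays open: the limit of > 20000 nM in this assay, at which 2 of the 3 values shown sit. Compound 1 and compound 3 both stand at limits, the step between them cannot be read, and of the three compounds only compound 2, with its 2-chlorophenyl, has a true number.

Going by these compounds, the swap alters both the halogen and its place on the ring, so it remains open which of the two carries the step; 2-fluorophenyl or 4-chlorophenyl on the same carbonyl carbon would separate them. On these data alone, whether an unsubstituted phenyl there would give a true number also stays open.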